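Shrinking the Amine Substituent on a Sulfonylindole Core

The source may report more compounds than this note shows. Statements on the series, on what has been measured and on what is new or still open speak of the compounds shown alone.

Two compounds share a core and differ only in the amine attached to it. Compound 1 `CN1CCN(c2ccc3ccn(S(=O)(=O)c4ccccc4)c3c2)CC1` gives 9 nM in an assay on isolated protein for displacement of a labelled ligand from 5-hydroxytryptamine receptor 6 (Homo sapiens), read by scintillation counting, with a stated time of 1 h; a lower number here means a stronger inhibitor, a higher number a weaker inhibitor. Among the measured compounds shown here, compound 2 `O=S(=O)(c1ccccc1)n1ccc2ccc(N3CCCCC3)cc21` gives 403 nM in this assay, the higher of the two numbers; the only recorded step, a 45-fold higher number from compound 1 to compound 2 (1.65 log units; beyond the scatter), shows that the group at this position can shift the result strongly. Compound 3 `CN(C)c1ccc2ccn(S(=O)(=O)c3ccccc3)c2c1` carries a smaller open-chain amine at the same place: dimethylamino in place of piperidin-1-yl on an aromatic carbon. For the measured compounds named here, no measured step covers this particular exchange, so the expectation rests on the step from compound 1 to compound 2 alone, which shows only that changes here can be large, not which way a ring-opening will go. A modest change, possibly toward a weaker inhibitor, is therefore expected, as a 1.5-fold higher number from compound 2 to compound 3 (0.17 log units; within the scatter). Compound 3 is estimated at 600 nM, within a range of 150 nM to 2500 nM.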

Compound 3, inhibition constant: 211 nM
Estimate against measurement, compound 3: 2.8-fold (0.45 log units) above; the measured number falls inside the stated range.
By their numbers in this assay, from the lowest: compound 1; then compounds 3 and 2 (each within the scatter of the next).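

Trading the piperidin-1-yl ring for the open-chain dimethylamino group leaves the two compounds apart by only a 1.9-fold lower number from compound 2 to compound 3 (0.28 log units; within the scatter), so neither the ring nor the larger size of this amine separates them here. The exchange from 4-methylpiperazin-1-yl to the same dimethylamino group, by contrast, gives a 23-fold higher number from compound 1 to compound 3 (1.37 log units; beyond the scatter), a large step like the one seen with piperidin-1-yl. Across these three compounds, then, two quite different replacements both land far from compound 1, and the large gap goes with the loss of 4-methylpiperazin-1-yl itself rather than with the particular amine that takes its place.

Nothing available explains why this group matters. Going by these compounds, it also remains open whether a piperazin-1-yl group without the methyl, or a morpholin-4-yl ring, would stay close to compound 1 or fall with compound 2 and compound 3.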